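Bromo to Nitro on the Aromatic Ring: An Estimate

The source may report more compounds than this note shows. Statements on the series, on what has been measured and on what is new or still open speak of the compounds shown alone.

Three measured compounds share one core and differ only in the group on an aromatic carbon. Compound 1 `Cc1ccc(C(=O)NN2C(=O)NC3(CC3(C)C)C2=O)cc1` gives 100 mg/kg in a functional assay on the whole organism (Hindlimb) for inhibition, with Mus musculus as the target, with a stated time of 0.5 h; a higher number here means that more compound is needed for the effect, a lower number that less compound is needed. Compound 2 `CC1(C)CC12NC(=O)N(NC(=O)c1ccc(Cl)cc1)C2=O` gives 100 mg/kg in this assay, and the step of no change at the digits printed from compound 1 to compound 2 (within the scatter). Compound 3 `CC1(C)CC12NC(=O)N(NC(=O)c1ccc(Br)cc1)C2=O` gives 300 mg/kg in this assay, the highest number of the three; the steps of a 3.0-fold higher number from compound 1 to compound 3 (0.48 log units; beyond the scatter) and a 3.0-fold higher number from compound 2 to compound 3 (0.48 log units; beyond the scatter) both move upward by the same modest amount.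

Compound 4 `CC1(C)CC12NC(=O)N(NC(=O)c1ccc([N+](=O)[O-])cc1)C2=O` has not been measured. Its change from compound 3 is nitro in place of bromo on an aromatic carbon. Going by the values given here, none of the measured steps involves a nitro group, so none bears on this change directly; they show only that swapping the group on that aromatic carbon can leave the number unchanged or move it modestly upward. A modest shift in either direction is therefore plausible, and the expectation is loose. Compound 4 is estimated at 200 mg/kg in this assay, with a range from 100 mg/kg to 600 mg/kg. The expected step is a 1.5-fold lower number from compound 3 to compound 4 (0.18 log units; within the scatter).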

Compound 4, minimum effective dose: 300 mg/kg
Estimate against measurement, compound 4: 1.5-fold (0.18 log units) below; the range from low to high includes it.
By their numbers in this assay, from the lowest: compounds 1 and 2 (each within the scatter of the next); then compounds 3 and 4 (each within the scatter of the next).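

In this assay the swap of bromo for nitro gives no change at the digits printed from compound 3 to compound 4 (within the scatter) even though nitro has more heavy atoms and brings hydrogen-bond acceptors that bromo lacks. Set against the other two groups, nitro gives a 3.0-fold higher number from compound 2 to compound 4 (0.48 log units; beyond the scatter) and a 3.0-fold higher number from compound 1 to compound 4 (0.48 log units; beyond the scatter) so the four compounds now form two levels on this aromatic carbon, with methyl and chloro at the lower number and bromo and nitro at the higher. Nothing available here explains why the groups pair up in this way.

Going by these compounds, whether these two levels extend to other groups remains open, for instance an amine or a carboxylic acid on the same carbon. Also open, on these data alone, is what a plain hydrogen there would give in this assay as a baseline for all four groups.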